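The compounds below may be only part of what the source reports. "The series", "measured", "known", "first", "only" and "open" are said of these compounds alone.

The measured compounds and their values in an ADME assay on the whole organism (strain Sprague-Dawley) for pharmacokinetics, with Rattus norvegicus as the target, read by LC-MS; a higher number here means that a larger share of the oral dose reaches the circulation, a lower number that a smaller share of the oral dose reaches the circulation:
compound 1 `O=C(COc1nn(-c2ccccc2F)c2ccc(F)cc12)N1CCOCC1` gives 22%;
compound 2 `CC(Oc1nn(-c2ccccc2F)c2ccc(F)cc12)C(=O)N1CCOCC1` gives 27%.

In this assay compound 1 holds the lowest of the two numbers, and compound 2 is its nearest neighbour at a number 5 percentage points higher from compound 1 to compound 2 (within the scatter), a step made by putting methyl in place of hydrogen on a saturated chain carbon bound to a carbonyl carbon and an oxygen on an aromatic ring. Compound 3 `O=c1[nH]ccn1CCOc1nn(-c2ccccc2F)c2ccc(F)cc12` departs from compound 1 differently: a group of 7 heavy atoms (4 carbon, 2 nitrogen, 1 oxygen; one five-membered aromatic ring with 2 hetero atoms) in place of a group of 8 heavy atoms (5 carbon, 1 nitrogen, 2 oxygen; one six-membered non-aromatic ring with 2 hetero atoms), on a saturated chain carbon bound to an oxygen on an aromatic ring. For the measured compounds named here, no measured step tests a change of this kind; the only measured step, a number 5 percentage points higher from compound 1 to compound 2 (within the scatter), touches another part of the molecule and stays within the scatter. There is therefore no ground for expecting a move beyond the scatter in either direction, though the uncertainty is wide. Compound 3 is expected to give 20%, within 5% to 40%, an expected step of a number 2 percentage points lower from compound 1 to compound 3 (within the scatter).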

Compound 3, oral bioavailability: 35%
The estimate for compound 3 lay 15 percentage points below the measured number; the range from low to high includes it.
By their numbers in this assay, from the lowest: compounds 1, 2 and 3 (each within the scatter of the next, the first and the last beyond it).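

In this assay, the group on the saturated chain carbon bound to an oxygen on an aromatic ring proves able to shift the result: replacing the (morpholin-4-yl)carbonyl with a five-membered aromatic ring with 2 hetero atoms gives a number 13 percentage points higher from compound 1 to compound 3 (beyond the scatter). This single swap alters several features at once, including the ring size, the ring type and the hydrogen-bond donors (0 in the group that leaves, 1 in the group that enters), so the step cannot be assigned to any one of them. Nothing at hand explains the rise.

As far as these compounds go, it remains open whether the number would hold with a methyl group in place of the hydrogen on the ring nitrogen of compound 3. Also open, from the compounds shown here alone, is what a longer chain carrying the same ring would do.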